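A few compounds are considered here, and "the series" means these few. Any claim that something is new, unique, unknown or untested is made for them only; others in the source may bear on it.

Measured compounds:
Compound 1, `ClCc1ccc(Cn2cnc3c(Cl)ncnc32)cc1`, gives 4670 nM in a functional assay on TK-10 cells (Homo sapiens) for cytotoxicity, read by sulforhodamine B assay, with a stated time of 48 h; a lower number here means a stronger inhibitor of growth, a higher number a weaker inhibitor of growth.
Compound 2, `ClCc1ccccc1Cn1cnc2c(Cl)nc(Cl)nc21`, gives 2880 nM in this assay.
Compound 3, `ClCc1ccc(Cn2cnc3nc(Cl)nc(Cl)c32)cc1`, gives 290 nM in this assay.

Three compounds share a fused two-ring core carrying a benzyl group that bears a chloromethyl substituent. Compound 2 has the second highest of the three numbers in this assay. Its nearest neighbour is compound 1, whose number is within the usual scatter of that of compound 2, so the two cannot be told apart on these data. Compound 3 stands apart: its number is well beyond the scatter below that of compound 2, so compound 3 is the stronger growth inhibitor of the pair.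

Compound 4, `Nc1nc(Cl)c2ncn(Cc3ccccc3CCl)c2n1`, has not yet been measured. It arises from compound 2 by amino in place of chloro on an aromatic carbon. Going by the values given here, no measured pair differs at this position alone, so there is no comparable step to lean on. An amino group entering between two ring nitrogen atoms is a change of a different kind from anything seen among the three measured compounds, and the direction of its effect cannot be read from them. The safest expectation is a step from compound 2 to compound 4 of modest size, if any, with a wide range on either side: a 1.6-fold higher number from compound 2 to compound 4 (0.19 log units; within the scatter) is the estimated step. Compound 4 is therefore expected to give about 4500 nM in this assay, with a plausible range from 1500 nM to 14000 nM.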

Compound 4, concentration for total growth inhibition: 36300 nM
Compound 4: middle estimate off by 8.1-fold (0.91 log units), on the low side; measured number above the stated range.
By their numbers in this assay, from the lowest: compound 3; then compounds 2 and 1 (each within the scatter of the next); then compound 4.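

Exchanging chloro for amino on the aromatic carbon between two ring nitrogen atoms gives a 13-fold higher number from compound 2 to compound 4 (1.10 log units; beyond the scatter) in this assay, so this position is not indifferent to what it carries: this one change leaves a much weaker inhibitor of growth. Going by these compounds alone, it is the first step that isolates a single position, and it shows that swapping one heavy atom for another can be enough to move the number well beyond the scatter, even though the amino group adds only a hydrogen-bond donor and acceptor that chloro lacks. Nothing measured here shows what lies behind the loss, so the step records an outcome and not a mechanism.

As far as these compounds go, a single pair cannot separate losing the chloro from gaining the amino, so it remains open whether a fluoro, methoxy or methylamino group at this carbon would keep the number near that of compound 2. From the compounds shown here alone, it is also open whether the same exchange would cost as much on the core of compound 3, which has a different attachment pattern.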